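The source may hold more compounds than are shown below. What is called first, only, known or untested is meant among the compounds shown, and "the series" means these compounds.

Measured in a physicochemical assay for solubility, measured as kinetic solubility; on this read-out lower numbers stand for lower solubility and higher numbers for higher solubility:

- Compound 1 `CC(=O)Nc1cc(-c2ccc(N(C)C(=O)c3c(F)cccc3Cl)c(N3CC4CC4C3)c2)n(C2CCCC2)n1` gives 0.1 ug/mL
- Compound 2 `CC(=O)Nc1cc(-c2ccc(N(C)C(=O)c3c(F)cccc3Cl)c(N3CCCCC3)c2)n(C(C)C)n1` gives 1.3 ug/mL
- Compound 3 `CC(=O)Nc1cc(-c2ccc(N(C)C(=O)c3c(F)cccc3Cl)c(N3CC4CC4C3)c2)n(C(C)C)n1` gives 2.1 ug/mL

Compound 3, at 2.1 ug/mL, cannot be told apart from compound 2, given a 1.6-fold higher number from compound 2 to compound 3 (0.21 log units; within the scatter). It stands clearly clear of compound 1, with a 21-fold higher number from compound 1 to compound 3 (1.32 log units; beyond the scatter).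

The next compound, compound 4 `CC(=O)Nc1cc(-c2ccc(N(C)C(=O)c3c(C)cccc3F)c(N3CC4CC4C3)c2)n(C(C)C)n1`, changes a different part of the molecule: methyl in place of chloro on an aromatic carbon. This turns the 2-chloro-6-fluorophenyl group into a 2-fluoro-6-methylphenyl group, and the rest of compound 3 stays as it is.

Neither measured step bears directly on this change. The large one, a 21-fold higher number from compound 1 to compound 3 (1.32 log units; beyond the scatter), swaps cyclopentyl for isopropyl on an aromatic nitrogen, and the other, a 1.6-fold higher number from compound 2 to compound 3 (0.21 log units; within the scatter), exchanges the ring group on an aromatic carbon of the core. Among the compounds with values here, the data hold no step at the place that now changes, so no shift beyond the scatter is expected in this assay. The estimated step is a 1.1-fold lower number from compound 3 to compound 4 (0.02 log units; within the scatter). For compound 4 the expected value is 2 ug/mL, with an estimated range of 0.7 ug/mL to 6 ug/mL.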

Compound 4, solubility: 17 ug/mL
For compound 4 the middle estimate is 8.5-fold (0.93 log units) below the measured one, and the stated range ends below it.
By their numbers in this assay, from the lowest: compound 1; then compounds 2 and 3 (each within the scatter of the next); then compound 4.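

In this assay, the 2-chloro-6-fluorophenyl group proves not to be a silent part of the molecule: methyl in place of chloro gives an 8.1-fold higher number from compound 3 to compound 4 (0.91 log units; beyond the scatter), the first step read at this place. The exchange is one heavy atom for one heavy atom, with no hydrogen-bond donor, no acceptor and no net charge on either side, so these counts do not separate the two groups. Nothing measured on these compounds accounts for the step.

Going by these compounds, the change is read on a single pair, so it remains open whether it would carry over to the cyclopentyl compounds or to those with the six-membered non-aromatic ring on the shared core. Also open, on these data alone, is what a methoxy group, a nitrile or plain hydrogen would do at this place, and what replacing the fluoro group would do.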